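Swapping a methylphenyl for a difluorophenyl on the amide

This account rests on a few compounds, and the source may have more. Where it says the series, first, only, none or still open, it means among the compounds named here.

Measured so far:
Compound 1 `O=C(Nc1cccc(-c2oc3cc(-c4ccc(F)cc4)ccc3c(=O)c2O)c1)c1ccc(F)cc1F` gives 9640 nM in a functional assay on GTL 16 cells for antiproliferative activity against GTL 16 cell line (Homo sapiens), read by CCK-8 assay, with a stated time of 72 h; a lower number here means a stronger inhibitor, a higher number a weaker inhibitor.
Compound 2 `Cc1ccccc1C(=O)Nc1cccc(-c2oc3cc(-c4ccc(F)cc4)ccc3c(=O)c2O)c1` gives 24800 nM in this assay.
Compound 3 `Cc1cccc(C(=O)Nc2cccc(-c3oc4cc(-c5ccc(F)cc5)ccc4c(=O)c3O)c2)c1` gives 10900 nM in this assay.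

Of the three numbers, that of compound 3 is the second highest. Its nearest neighbour is compound 1, as the step of a 1.1-fold higher number from compound 1 to compound 3 (0.05 log units; within the scatter) lies within the scatter, so the two cannot be told apart. The step of a 2.3-fold lower number from compound 2 to compound 3 (0.36 log units; beyond the scatter) is beyond the scatter but modest.

Compound 4 `O=C(Nc1cccc(-c2oc3cc(-c4ccc(F)cc4)ccc3c(=O)c2O)c1)c1cc(F)cc(F)c1` has not yet been measured. The change from compound 3 is 3,5-difluorophenyl in place of 3-methylphenyl on a carbonyl carbon. Among the compounds with values here, two measured steps bear on it: a 1.1-fold higher number from compound 1 to compound 3 (0.05 log units; within the scatter) shows that exchanging a fluorinated phenyl for a methylphenyl on the carbonyl carbon left the number unchanged within the scatter, while a 2.3-fold lower number from compound 2 to compound 3 (0.36 log units; beyond the scatter) shows that the pattern on that phenyl can matter modestly. Because a 1.1-fold higher number from compound 1 to compound 3 (0.05 log units; within the scatter) is within the scatter, compound 4 is expected to show no step beyond the scatter, a 1.1-fold lower number from compound 3 to compound 4 (0.06 log units; within the scatter). The estimate for compound 4 in this assay is therefore 9500 nM, with a range from 4000 nM to 25000 nM.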

Compound 4, half-maximal inhibitory concentration: 7410 nM
Compound 4: middle estimate off by 1.3-fold (0.11 log units), on the high side; the measured number falls inside the stated range.
By their numbers in this assay, from the lowest: compounds 4, 1 and 3 (each within the scatter of the next); then compound 2.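

In this assay, the 3,5-difluorophenyl group on the carbonyl carbon cannot be told apart from the 3-methylphenyl group (a 1.5-fold lower number from compound 3 to compound 4 (0.17 log units; within the scatter)) or from the 2,4-difluorophenyl group (a 1.3-fold lower number from compound 1 to compound 4 (0.11 log units; within the scatter)), so a second fluorine pattern gives a result within the scatter of the other two. Among the four compounds, only compound 2, with its 2-methylphenyl group, stands apart from this cluster, and the new comparison (a 3.3-fold lower number from compound 2 to compound 4 (0.52 log units; beyond the scatter)) is a modest step, the largest yet seen at this position. No measurement shown here explains why the 2-methylphenyl group differs.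

Within the data shown here, every group at this position so far is a phenyl ring carrying only methyl or fluorine, so it remains open whether an amine or a carboxylic acid on that ring would move the number beyond the scatter. From the compounds shown here alone, a longer alkyl chain in place of the methyl is equally open.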